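The source may hold more compounds than are shown below. What is called first, only, known or untested is meant among the compounds shown, and "the series" means these compounds.

Working notes on the series. Three members have been run in a functional assay on U-937 cells (Homo sapiens) for antiproliferative activity, read by MTT assay, with a stated time of 24 h; on this read-out lower numbers stand for stronger inhibition and higher numbers for weaker inhibition. Compound 1 `O=C1O/C(=C\Cn2cc(-c3ccccc3)nn2)C(OCc2ccccc2)=C1OCc1ccccc1` returns only a limit of the assay, > 100000 nM. Compound 3 `O=C1O/C(=C\Cn2cc(Cc3ccccc3)nn2)C(OCc2ccccc2)=C1OCc1ccccc1` likewise returns only a limit, > 100000 nM. Between these two, the change of benzyl in place of phenyl on an aromatic carbon gives a step that the two limits leave unreadable from compound 1 to compound 3, so that step cannot be read. Within the data shown here, compound 2 `Cc1ccc(-c2cn(CCC3(O)NC(=O)C(OCc4ccccc4)=C3OCc3ccccc3)nn2)cc1` is the one member with an actual number: in this assay compound 2 gives 54000 nM. It therefore stands alone as the only numbered point, the other two values being limits, as the limit of > 100000 nM in this assay, at which 2 of the 3 values shown sit, records.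

Compound 4 `O=C1NC(O)(CCn2cc(C3=CCCCC3)nn2)C(OCc2ccccc2)=C1OCc1ccccc1` is the next member to be run. It differs from compound 2 by cyclohex-1-en-1-yl in place of 4-methylphenyl on an aromatic carbon. Among the measured compounds shown here, no measured step covers a change of this kind; the single step that has been run, from compound 1 to compound 3, is unreadable, and it concerns a different pair of groups on the other core. There is thus no measured basis for expecting a move beyond the usual scatter in either direction. The expected step of a 1.1-fold higher number from compound 2 to compound 4 (0.05 log units; within the scatter) is taken to lie within that scatter. Compound 4 is accordingly expected at 60000 nM, with a range from 20000 nM to 150000 nM.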

Compound 4, half-maximal inhibitory concentration: > 100000 nM
Compound 4: a limit, no number (the forecaster's own chance of this, stated with the estimate: 35%); middle value at least 1.6-fold (0.22 log units) from the limit.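

Among these compounds, this is the first readable step at this position: cyclohex-1-en-1-yl in place of 4-methylphenyl, on an aromatic carbon of a five-membered aromatic ring with 3 nitrogen, gives an at least 1.8-fold higher number from compound 2 to compound 4 (0.26 log units; that floor lies within the scatter). From the compounds shown here alone, only a floor is available, so the step establishes no change beyond the usual scatter, and its true size stays unknown. Compound 2 remains the only member with a number, and its one measured neighbour at this position gives no second number, so the series still rests mostly on one assay limit: the limit of > 100000 nM in this assay, at which 3 of the 4 values shown sit.

The compounds shown do not tell whether a saturated cyclohexyl, a 4-methoxyphenyl or a pyridyl group at this position would return a number, so the part played by the aromatic ring of 4-methylphenyl stays unresolved. Also open, going by these compounds, is whether free hydroxyl groups in place of the two benzyloxy groups on the shared core would bring any member into the measurable range, and whether the phenyl and benzyl pair would give a readable step on the core of compound 2.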